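The source may report more compounds than this note shows. Statements on the series, on what has been measured and on what is new or still open speak of the compounds shown alone.

Measured so far:
compound 1, `COc1ccc(C2=C(c3cc(OC)c(OC)c(OC)c3)C(=O)C(OC(C)=O)C2)cc1F`: 39.5 ug/mL
compound 2, `COc1ccc(C2=C(c3cc(OC)c(OC)c(OC)c3)CC(O[SiH2]C(C)(C)C)C2=O)cc1[N+](=O)[O-]`: > 100 ug/mL

For the measured compounds named here, compound 1 holds the only number recorded in an ADME assay on MIA PaCa-2 cells (Homo sapiens) for cytotoxicity, read by MTT assay, with a stated time of 72 h (on this read-out higher numbers stand for weaker inhibition and lower numbers for stronger inhibition), where compound 1 gives 39.5 ug/mL. For compound 2 the value in this assay is a limit of the assay, not a number, in line with the limit of > 100 ug/mL in this assay, at which 1 of the 2 values shown sits. Compound 3, `COc1ccc(C2=C(c3cc(OC)c(OC)c(OC)c3)C(=O)C(OC(C)=O)C2)cc1Cl`, is not yet measured; it differs from compound 1 by chloro in place of fluoro on an aromatic carbon, which cut one bond further out reads 3-fluoro-4-methoxyphenyl to 3-chloro-4-methoxyphenyl. Going by the values given here, no measured step in this assay is available to set the size of such a change. The expectation is a step of a 1.1-fold lower number from compound 1 to compound 3 (0.05 log units; within the scatter) that stays within the usual scatter, with no direction favoured. Compound 3 is therefore estimated at 35 ug/mL, in the range 15 ug/mL to 80 ug/mL.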

Compound 3, half-maximal inhibitory concentration: 24 ug/mL
Beside the measured number, compound 3's estimate is 1.5-fold (0.16 log units) above it, and the stated range covers the measured number.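

In this assay, chloro in place of fluoro on an aromatic carbon ortho to a methoxy group gives a 1.6-fold lower number from compound 1 to compound 3 (0.22 log units; within the scatter), so compound 1 and compound 3 read as one level and this place accepts either halogen. Nothing shown bears on a cause for this step.

Open, from the compounds shown here alone, is how a bromo, a nitrile or an amine at the same place would read. For the compounds shown here, compound 2 carries a limit of the assay, > 100 ug/mL, and differs from compound 3 in more than one place, so it sets no step.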